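The source may hold more compounds than are shown below. What is called first, only, known or untested is meant among the compounds shown, and "the series" means these compounds.

Working notes on the series. In a functional assay on HL-60 cells (Homo sapiens) for cytotoxicity, read by luminescence and CellTiter-Glo, with a stated time of 3 days (a lower number here means a stronger inhibitor, a higher number a weaker inhibitor), compound 1 (`O=C(Nc1cc(C(F)(F)F)cc(C(F)(F)F)c1)c1ccc(Br)cc1O`) gives 270 nM, compound 2 (`N#Cc1cccc(NC(=O)c2cc(F)ccc2O)c1`) gives 7750 nM and compound 3 (`O=C(Nc1cccc(C(F)(F)F)c1)c1cc(F)ccc1O`) gives 970 nM. Compound 3 therefore holds the middle place among the three numbers, closer to compound 1 than to compound 2, with both gaps beyond the scatter.

The next compound, compound 4 (`O=C(Nc1cc(C(F)(F)F)cc(C(F)(F)F)c1)c1cc(F)ccc1O`), carries one change from compound 3: trifluoromethyl in place of hydrogen on an aromatic carbon. Trifluoromethyl takes the place of hydrogen on an aromatic carbon, meta to a trifluoromethyl group.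

Within the data shown here, only one measured step involves a trifluoromethyl group entering: an 8.0-fold lower number from compound 2 to compound 3 (0.90 log units; beyond the scatter). It lies beyond the scatter, but there the group replaces cyano rather than hydrogen, so it guides the size of the new step only loosely. Compound 4 has the same two trifluoromethyl groups as compound 1, and compound 1 gives 270 nM, a lower number than that of compound 3, but it also differs elsewhere in the core. Among the measured compounds shown here, no measured pair isolates the new change.

A modest move to a lower number in this assay is expected, and the estimated step is a 3.2-fold lower number from compound 3 to compound 4 (0.51 log units; beyond the scatter). For compound 4 the expected value is 300 nM, with an estimated range from 120 nM to 750 nM.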

Compound 4, half-maximal inhibitory concentration: 320 nM
Compound 4: the middle estimate sits 1.1-fold (0.03 log units) below what was measured; the range from low to high includes it.
By their numbers in this assay, from the lowest: compounds 1 and 4 (each within the scatter of the next); then compound 3; then compound 2.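

In this assay, among these compounds, trifluoromethyl in place of hydrogen on the aromatic carbon meta to a trifluoromethyl group gives a 3.0-fold lower number from compound 3 to compound 4 (0.48 log units; beyond the scatter), the first measured step in which this group replaces hydrogen rather than cyano, and it lies beyond the scatter. With both trifluoromethyl groups present, 5-fluoro-2-hydroxyphenyl in place of 4-bromo-2-hydroxyphenyl on the carbonyl carbon gives a 1.2-fold higher number from compound 1 to compound 4 (0.07 log units; within the scatter), a step within the scatter, so this exchange does not separate the two compounds in this assay. No available evidence bears on the reason for either step.

The compounds shown carry only hydrogen or trifluoromethyl at this position, so the effect of an amine, a carboxylic acid or a longer chain there remains an open question. On these data alone, the size of the same hydrogen-to-trifluoromethyl step on the core of compound 1 also stays open.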